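The source may report more compounds than this note shows. Statements on the series, on what has been measured and on what is new or still open speak of the compounds shown alone.

Measured so far in a toxicity assay on GES1 cells (Homo sapiens) for inhibition, read by MTT assay, with a stated time of 72 h; a higher number here means a weaker inhibitor, a lower number a stronger inhibitor:
- compound 1, `Cc1cc(N2CC[C@@H](C)[C@@H](N(C)c3ncnc4[nH]ccc34)C2)n2nc(SCC3CC3)nc2n1`: 27900 nM
- compound 2, `C=CCSc1nc2nc(C)cc(N3CC[C@@H](C)[C@@H](N(C)c4ncnc5[nH]ccc45)C3)n2n1`: > 100000 nM, which is a limit of the assay and not a number
- compound 3, `Cc1cc(N2CC[C@@H](C)[C@@H](N(C)c3ncnc4[nH]ccc34)C2)n2nc(SCc3ccc(Br)cc3)nc2n1`: 55600 nM

Compound 1 stands lowest of the two numbers shown; its nearest neighbour is compound 3, with a 2.0-fold higher number from compound 1 to compound 3 (0.30 log units; within the scatter). The third value belongs to compound 2 and is only a limit, (the limit of > 100000 nM in this assay, at which 1 of the 3 values shown sits).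

Compound 4 is `Cc1cc(N2CC[C@@H](C)[C@@H](N(C)c3ncnc4[nH]ccc34)C2)n2nc(SCc3ccc(F)cc3)nc2n1`. It differs from compound 1 by 4-fluorophenyl in place of cyclopropyl on a saturated chain carbon bound to a sulfur.

Going by the values given here, the step that bears most directly on this change is the one from compound 1 to compound 3, where a 4-bromophenyl enters at the same saturated chain carbon bound to a sulfur: a 2.0-fold higher number from compound 1 to compound 3 (0.30 log units; within the scatter). The step to compound 2, an at least 3.5-fold higher number from compound 1 to compound 2 (0.55 log units; beyond the scatter), puts a vinyl in that place and reached the limit, so it is less informative. A 4-fluorophenyl is expected to behave much like the 4-bromophenyl of compound 3, so for compound 4 the expected step is a 1.6-fold higher number from compound 1 to compound 4 (0.21 log units; within the scatter), a number only mildly higher and within the scatter.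

Compound 4 is therefore estimated at 45000 nM in this assay, with a range of 20000 nM to 100000 nM.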

Compound 4, half-maximal inhibitory concentration: 12300 nM
Compound 4: the middle estimate sits 3.7-fold (0.56 log units) above what was measured, and the stated range ends above it.
By their numbers in this assay, from the lowest: compound 4; then compounds 1 and 3 (each within the scatter of the next). At a limit, above all of these: compound 2.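

In this assay, 4-fluorophenyl in place of cyclopropyl on a saturated chain carbon bound to a sulfur gives a 2.3-fold lower number from compound 1 to compound 4 (0.36 log units; beyond the scatter) and so shows that an aromatic ring at this place can lower the number beyond the scatter, which compound 3 did not show. Fluoro in place of bromo on an aromatic carbon gives a 4.5-fold lower number from compound 3 to compound 4 (0.66 log units; beyond the scatter) and shows that the halogen alone separates the two compounds carrying an aromatic ring. Compound 2 holds a limit and not a number, so an at least 8.1-fold lower number from compound 2 to compound 4 (0.91 log units; beyond the scatter) gives only a floor for the change from vinyl to 4-fluorophenyl.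

On these data alone, whether a chloro, a methoxy or an amine on that aromatic carbon would follow compound 4 or compound 3 remains open. Also open, as far as these compounds go, is how a longer chain in place of the cyclopropyl would read in this assay at this place.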